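Lengthening the carbonyl substituent of compound 2

This account rests on a few compounds, and the source may have more. Where it says the series, first, only, none or still open, it means among the compounds named here.

Measured in an in vitro ADME assay on microsomes from liver (Homo sapiens) for metabolic stability, tested at 1 uM; on this read-out lower numbers stand for a shorter-lived compound and higher numbers for a longer-lived compound:
Compound 1 `CC(C)(O)CCN1CCC(NS(=O)(=O)c2cc(S(=O)(=O)c3ccccc3)ccc2C(F)(F)F)CC1`: < 0.0167 h, a limit
Compound 2 `O=C(C1CCNCC1)N1CCC(NS(=O)(=O)c2cc(S(=O)(=O)c3ccccc3)ccc2C(F)(F)F)CC1`: > 0.5 h, a limit

In this assay compound 2 stands at > 0.5 h, which is a limit of the assay and not a number. Compound 3 `O=C(CC1CCNCC1)N1CCC(NS(=O)(=O)c2cc(S(=O)(=O)c3ccccc3)ccc2C(F)(F)F)CC1` carries (piperidin-4-yl)methyl in place of piperidin-4-yl on a carbonyl carbon. Among the measured compounds shown here, one measured step bears on this change, and it is an at least 29-fold higher number from compound 1 to compound 2 (1.47 log units; beyond the scatter), large and beyond the scatter. That step exchanged a whole group on an amine nitrogen in a ring, whereas compound 3 keeps the carbonyl of compound 2 and differs only by the change described. A step of that size is therefore not expected here. The expected step is a number no higher from compound 2 to compound 3 (the limit leaves the size open), with none expected beyond the scatter. For compound 3 the estimated half-life is 0.5 h, with an expected range of 0.25 h to 1 h.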

Compound 3, half-life: > 0.5 h
Compound 3: only a limit was reported (the forecaster's own chance of this, stated with the estimate: 55%); the middle value sits exactly at the limit.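

The change adds no readable information on size in this assay because compound 2 and compound 3 sit at the same limit, so the step between them cannot be read: the limit of > 0.5 h in this assay, at which 2 of the 3 values shown sit. The large gap from the compound with the 3-hydroxy-3-methylbutyl group on the ring nitrogen is kept with the longer group on the carbonyl carbon (an at least 29-fold higher number from compound 1 to compound 3 (1.47 log units; beyond the scatter)). On this carbonyl carbon, piperidin-4-yl and (piperidin-4-yl)methyl therefore both leave the half-life at the limit, and no loss shows within the range of the assay.

On these data alone, how far compound 2 and compound 3 lie beyond that limit remains open, as does any difference between them. Also open, as far as these compounds go, is what a longer chain or a carboxylic acid on this carbonyl carbon would give in this assay.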